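Carbamoyl to fluoro on the aryl ring of compound 3

The source may report more compounds than this note shows. Statements on the series, on what has been measured and on what is new or still open speak of the compounds shown alone.

Measured so far:
compound 1 `C=CC[C@H]1C[C@]2(CCc3ccc(OC)c(OC)c3)OCOC2=CC1=O`: 3200 nM
compound 2 `C=CC[C@H]1C[C@]2([C@@H](C)Cc3ccc(OC(F)(F)F)cc3)OCOC2=CC1=O`: 3800 nM
compound 3 `C=CC[C@H]1C[C@]2([C@@H](C)Cc3ccc(OC)c(C(N)=O)c3)OCOC2=CC1=O`: 66 nM

All three were run in a functional assay on NCI-H460 cells (Homo sapiens) for antiproliferative activity, with a stated time of 72 h; on this read-out lower numbers stand for stronger inhibition and higher numbers for weaker inhibition. Compound 3 carries the lowest number of the three; compound 1 and compound 2 both sit well beyond the scatter of it, so compound 3 is the most potent of the measured set. Compound 1 and compound 2 lie within the scatter of each other, so no order between those two can be read.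

Compound 4 `C=CC[C@H]1C[C@]2([C@@H](C)Cc3ccc(OC)c(F)c3)OCOC2=CC1=O` keeps the core and side chain of compound 3 and differs in one place: fluoro in place of carbamoyl on an aromatic carbon. Within the data shown here, the group that leaves is the one feature that sets compound 3 apart from compound 1 and compound 2 on the aryl ring, and with it go the only hydrogen-bond donor and acceptor on that ring. Among the measured compounds shown here, no measured pair isolates this change, so the size of the step rests on the spread between compound 3 and the other two.

Compound 4 is expected to lose potency, with a step of a 12-fold higher number from compound 3 to compound 4 (1.08 log units; beyond the scatter) that goes beyond the scatter but does not need to reach the level of compound 1. The estimate for compound 4 in this assay is 800 nM, within 200 nM to 3000 nM.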

Compound 4, half-maximal inhibitory concentration: 90 nM
The estimate for compound 4 lay 8.9-fold (0.95 log units) above the measured number; measured number outside the range, below it.
By their numbers in this assay, from the lowest: compounds 3 and 4 (each within the scatter of the next); then compounds 1 and 2 (each within the scatter of the next).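

Fluoro in place of carbamoyl on the aromatic carbon ortho to a methoxy group gives a 1.4-fold higher number from compound 3 to compound 4 (0.13 log units; within the scatter) in this assay, so this pair shows no readable difference at this position. Within this pair, a number in this range therefore does not depend on the carbamoyl group: fluoro, with 1 heavy atom and 0 hydrogen-bond donors or acceptors, gives a value that cannot be told apart from that of the larger group, so the hydrogen-bond donor and acceptor of carbamoyl are not needed here in this assay. No measurement is available that bears on why the two compounds read alike.

The compounds shown leave open whether this position accepts any group at all, since neither a plain hydrogen nor other replacements such as chloro, a nitrile, an amine or a carboxylic acid appear at this aromatic carbon with the rest of compound 3 held constant. They also leave open whether the match between carbamoyl and fluoro holds with the methoxy group replaced, for instance by an ethoxy group or a hydroxyl.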